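Butyl in place of 2-fluorophenyl on a shared core

A few compounds are considered here, and "the series" means these few. Any claim that something is new, unique, unknown or untested is made for them only; others in the source may bear on it.

Compound 1 `O=C(c1ccccc1F)N1CCN(c2nc(=O)c3cc(C(F)(F)F)cc([N+](=O)[O-])c3s2)CC1` is the less soluble of the two measured compounds: in a physicochemical assay for solubility, read by HPLC (a higher number here means a more soluble compound, a lower number a less soluble compound), compound 1 gives 3.1 ug/mL, the lowest of the two numbers. Among the compounds with values here, compound 2 `CCC(C)C(=O)N1CCN(c2nc(=O)c3cc(C(F)(F)F)cc([N+](=O)[O-])c3s2)CC1` carries sec-butyl on the carbonyl carbon instead, and in this assay compound 2 gives 104 ug/mL; the single measured step, a 34-fold higher number from compound 1 to compound 2 (1.53 log units; beyond the scatter), is large. Compound 3 `CCCCC(=O)N1CCN(c2nc(=O)c3cc(C(F)(F)F)cc([N+](=O)[O-])c3s2)CC1` differs from compound 1 in one place: butyl in place of 2-fluorophenyl on a carbonyl carbon. The step from compound 1 to compound 2 is the one that bears on this change, as sec-butyl and butyl differ only in branching, and it was large. A step of similar size and direction is therefore expected for compound 3: a 26-fold higher number from compound 1 to compound 3 (1.41 log units; beyond the scatter). Compound 3 is expected to give about 80 ug/mL in this assay, with a range from 30 ug/mL to 200 ug/mL.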

Compound 3, solubility: 42.5 ug/mL
Compound 3: the middle estimate sits 1.9-fold (0.27 log units) above what was measured, within the range that was stated.
By their numbers in this assay, from the lowest: compound 1; then compound 3; then compound 2.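

In this assay, butyl in place of 2-fluorophenyl on the carbonyl carbon also gives a large rise (a 14-fold higher number from compound 1 to compound 3 (1.14 log units; beyond the scatter)), so the gain at this position is not confined to the branched sec-butyl group and holds for both chains shown. The two chains are not interchangeable, however: the unbranched chain falls modestly short of the branched one (a 2.4-fold lower number from compound 2 to compound 3 (0.39 log units; beyond the scatter)), so branching at this position still registers, though much less than leaving the 2-fluorophenyl group. Nothing shown here gives a reason for either step.

On these data alone, whether the low number of compound 1 goes with the ring itself or with its fluorine stays open, as a plain phenyl would be needed to separate them. Also open, as far as these compounds go, is how a longer chain, a cyclohexyl group or a chain bearing an amine would compare at this position.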